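Chain-length series on the shared core, then an inversion step

A few compounds are considered here, and "the series" means these few. Any claim that something is new, unique, unknown or untested is made for them only; others in the source may bear on it.

Three members carry a decyl, dodecyl or tetradecyl chain on the same triazole-linked core. In a functional assay on MGC-803 cells (Homo sapiens) for antiproliferative activity, read by MTT assay, with a stated time of 48 h (a lower number here means a stronger inhibitor, a higher number a weaker inhibitor), compound 1 `CCCCCCCCCCn1cc(COC[C@@H]2OC[C@H](N)[C@@H]2O)nn1` gives 8780 nM, compound 2 `CCCCCCCCCCCCn1cc(COC[C@@H]2OC[C@H](N)[C@@H]2O)nn1` gives 21400 nM, and compound 3 `CCCCCCCCCCCCCCn1cc(COC[C@@H]2OC[C@H](N)[C@@H]2O)nn1` gives 8210 nM. Compound 3 has the lowest of the three numbers, with compound 1 within the scatter and compound 2 beyond it. The measured steps are a 2.4-fold higher number from compound 1 to compound 2 (0.39 log units; beyond the scatter), a 1.1-fold lower number from compound 1 to compound 3 (0.03 log units; within the scatter) and a 2.6-fold lower number from compound 2 to compound 3 (0.42 log units; beyond the scatter), all of them chain-length steps.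

Compound 4 `CCCCCCCCCCCCCCn1cc(COC[C@@H]2OC[C@H](N)[C@H]2O)nn1` keeps the tetradecyl chain; (the two compounds have the same atoms and bonds and differ only in configuration as drawn: 1 of 3 stereo elements differ; a stereocentre at a saturated ring carbon is drawn S in compound 3 and R in compound 4). Going by the values given here, none of the three measured steps concerns configuration, so there is no measured step to size this change. Against that background, the step is expected to be a 1.2-fold higher number from compound 3 to compound 4 (0.09 log units; within the scatter), within the scatter but with a wide range either way. Compound 4 is estimated at 10000 nM, between 3000 nM and 40000 nM.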

Compound 4, half-maximal inhibitory concentration: 8790 nM
Beside the measured number, compound 4's estimate is 1.1-fold (0.06 log units) above it; the measured number falls inside the stated range.
By their numbers in this assay, from the lowest: compounds 3, 1 and 4 (each within the scatter of the next); then compound 2.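

In this assay, the stereocentre at a saturated ring carbon, drawn S then R, gives a 1.1-fold higher number from compound 3 to compound 4 (0.03 log units; within the scatter), the first size on record for a configuration change in this series. With the tetradecyl chain, inversion at this one centre leaves the number within the scatter. The reading isolates that single centre: the fact that compounds 3 and 4 differ only in the configuration as drawn

Open: whether the same inversion stays as small with the decyl or dodecyl chain, and what the other two stereo elements contribute. Also open, as far as these compounds go, is how a hexadecyl chain, or an acetamide in place of the amine, would read on either configuration.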